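The source may hold more compounds than are shown below. What is called first, only, known or untested is meant among the compounds shown, and "the series" means these compounds.

Compound 1, `C=CC1=C(C(=O)NCc2ccccc2)C(c2ccc(OC)c(OC)c2)OC1`, gives > 100000 nM in a functional assay on A549 cells (Homo sapiens) for cytotoxicity, read by MTT assay, with a stated time of 24 h (a lower number here means a stronger inhibitor, a higher number a weaker inhibitor), a limit of the assay.
Compound 2, `C=CC1=C(C(=O)NCCCCC)C(c2ccc(Cl)c(Cl)c2)OC1`, gives > 100000 nM in this assay, a limit of the assay.
Compound 3, `C=CC1=C(C(=O)O)C(c2ccc(OC)cc2)OC1`, gives > 100000 nM in this assay, a limit of the assay.

None of these three values is a number; each is a limit of the assay. Among the measured compounds shown here, compound 2 therefore stands at the same limit as the others, (the limit of > 100000 nM in this assay, at which 3 of the 3 values shown sit), and no step between measured compounds can be counted, since nothing in the measured set differs in a single place.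

Compound 4, `C=CC1=C(C(=O)Nc2ccccc2OC)C(c2ccc(Cl)c(Cl)c2)OC1`, has not yet been measured in this assay. It differs from compound 2 in one place: 2-methoxyphenyl in place of pentyl on an amide-type nitrogen. For the measured compounds named here, no measured pair shows the effect of such a change, and the three values shown give no direction at all. For compound 4 the expected step is a number no higher from compound 2 to compound 4 (the limit leaves the size open), nothing beyond the usual scatter. Compound 4 is therefore expected to come out near 100000 nM, within 30000 nM to 300000 nM, and most likely to be reported once more only as a limit.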

Compound 4, half-maximal inhibitory concentration: > 100000 nM
Compound 4: only a limit was reported; the forecaster's own chance of this, stated with the estimate: 80%; the middle value sits exactly at the limit.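

In this assay compound 4 gives > 100000 nM as a limit of the assay. Among the compounds shown here, compound 2 stands at the same limit, so no step from compound 2 to compound 4 can be read. The compounds shown leave open whether any group on the amide-type nitrogen would give a number rather than a limit.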